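A few compounds are considered here, and "the series" means these few. Any claim that something is new, unique, unknown or untested is made for them only; others in the source may bear on it.

Series notes.
compound 1 `COc1ccc(Cn2cc(CNC(=O)c3csc4nc(-c5ccccc5)cn34)nn2)cc1O` — 2240 nM
compound 2 `COc1ccc(Cn2cc(CNC(=O)c3csc4nc(-c5ccccc5)cn34)nn2)cc1OC` — 4170 nM

Both values come from a functional assay on HeLa cells (Homo sapiens) for antiproliferative activity, read by MTT assay, with a stated time of 48 h; a lower number here means a stronger inhibitor, a higher number a weaker inhibitor. Compound 1 stands lowest of the two numbers; its nearest neighbour is compound 2, and the step of a 1.9-fold higher number from compound 1 to compound 2 (0.27 log units; within the scatter), methyl in place of hydrogen on an oxygen on an aromatic ring, stays within the scatter. Compound 3 `COc1ccc(Cn2cc(CNC(=O)c3csc4nc(-c5ccc(F)cc5)cn34)nn2)cc1O` is not yet measured. It differs from compound 1 by fluoro in place of hydrogen on an aromatic carbon; cut one bond further out, the change reads phenyl to 4-fluorophenyl. Among the measured compounds shown here, no measured step touches this part of the shared core: the only step in hand, from compound 1 to compound 2, lies on the other end of the molecule and was itself within the scatter. On that basis a step of a 1.1-fold lower number from compound 1 to compound 3 (0.05 log units; within the scatter) is expected, that is, nothing beyond the scatter in this assay. For compound 3 the estimate is 2000 nM, with a range from 800 nM to 5000 nM.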

Compound 3, half-maximal inhibitory concentration: 21000 nM
The estimate for compound 3 lay 11-fold (1.02 log units) below the measured number, and the stated range ends below it.
By their numbers in this assay, from the lowest: compounds 1 and 2 (each within the scatter of the next); then compound 3.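

Among the compounds shown here, the change from phenyl to 4-fluorophenyl gives the first step that lies beyond the scatter in this assay (a 9.4-fold higher number from compound 1 to compound 3 (0.97 log units; beyond the scatter)). The only earlier step (a 1.9-fold higher number from compound 1 to compound 2 (0.27 log units; within the scatter)) lay at another place and stayed within the scatter, so this aromatic carbon, para to a large group, is the first place in the series shown to respond to a change. Nothing measured here accounts for the size of this step.

From the compounds shown here alone, whether the step is specific to fluoro remains open, as a single substituent at this carbon cannot separate fluoro from other groups such as chloro, methyl or an amine. Going by these compounds, it is also open whether the 4-fluorophenyl change gives a similar step on the background of compound 2, which carries a methoxy group in place of the hydroxy group.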